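Cyclopropylamino in place of the trifluoromethylphenylamino group

The source may hold more compounds than are shown below. What is called first, only, known or untested is meant among the compounds shown, and "the series" means these compounds.

Compound 1 `C=CC(=O)Nc1cc(Nc2ncc(C)c(Nc3ccccc3S(=O)(=O)C(C)C)n2)c(OC)cc1N1CCC(N2CCN(C)CC2)CC1` carries the shared core of the series. In a functional assay on NCI-H3122 cells (Homo sapiens) for inhibition, read by CellTiter-Glo, with a stated time of 72 h (on this read-out lower numbers stand for stronger inhibition of growth and higher numbers for weaker inhibition of growth), compound 1 reaches only a limit of the assay, < 0.3 nM, and no number is obtained (the limit of < 0.3 nM in this assay, at which 1 of the 2 values shown sits). Among the measured compounds shown here, compound 2 `C=CC(=O)Nc1cc(Nc2ncc(Cl)c(Nc3cccc(C(F)(F)F)c3)n2)c(OC)cc1N1CCN(C)CC1` is the one compound of the pair with a measured number: in this assay compound 2 gives 770 nM. Compound 3 `C=CC(=O)Nc1cc(Nc2ncc(Cl)c(NC3CC3)n2)c(OC)cc1N1CCN(C)CC1` differs from compound 2 by a single change, (cyclopropyl in place of 3-(trifluoromethyl)phenyl on a nitrogen on an aromatic ring), and has not yet been measured in this assay. For the measured compounds named here, no measured step of this kind stands, so the direction must be judged from the pair itself. The expectation is that compound 3 loses growth inhibition relative to compound 2 by a step beyond the usual scatter, a 4.5-fold higher number from compound 2 to compound 3 (0.66 log units; beyond the scatter). Compound 3 is therefore estimated at 3500 nM, with a plausible range from 900 nM to 15000 nM in this assay, and a real chance that only a limit is recorded.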

Compound 3, concentration for 50% growth inhibition: 3200 nM
Estimate against measurement, compound 3: 1.1-fold (0.04 log units) above; the measured number falls inside the stated range.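

In this assay, among the compounds shown here, the first measured step at this nitrogen on an aromatic ring is a 4.2-fold higher number from compound 2 to compound 3 (0.62 log units; beyond the scatter), a modest loss of growth inhibition on going from 3-(trifluoromethyl)phenyl to cyclopropyl. The aromatic ring is not needed to obtain a number at this place: compound 3 still gives 3200 nM rather than a limit of the assay. Nothing measured here gives a cause for the step.

From the compounds shown here alone, how the step divides between the phenyl ring and the trifluoromethyl group remains open, as both leave together; an unsubstituted phenyl or a cyclohexyl on the same nitrogen would separate the two. Also open, going by these compounds, is whether the same change carries the same cost with the methyl-substituted core and the piperidine-linked amine of compound 1.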